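This account rests on a few compounds, and the source may have more. Where it says the series, first, only, none or still open, it means among the compounds named here.

In a functional assay on the whole organism (Tail, strain ICR) with Mus musculus as the target, in the tail flick test, with a stated time of 90 min, at a dose of 25 umol/kg by the oral route (on this read-out higher numbers stand for a stronger effect at the one dose given and lower numbers for a weaker effect), three compounds have been measured:

compound 1, `O=C(CN(c1nc(Cl)nc2[nH]cnc12)C1CC1)N[C@@H](CO)C(=O)O`, gives 43.9%
compound 2, `NC(=O)C[C@H](NC(=O)CN(c1nc(Cl)nc2[nH]cnc12)C1CC1)C(=O)O`, gives 20.1%
compound 3, `O=C(CN(c1ncnc2c1ncn2C1CCCCO1)C1CC1)N[C@@H](CO)C(=O)OCc1ccccc1`, gives 32.2%

Compounds 1 and 2 share one core and differ in a single place: carbamoyl in place of hydroxy on a saturated chain carbon, two bonds along the chain from an amide-type nitrogen and a carbonyl carbon. That change made the step of a number 23.8 percentage points lower from compound 1 to compound 2 (beyond the scatter). Compound 3 carries a different core, and how the two cores differ is not broken down here; its value in this assay sits between those of compound 1 and compound 2.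

Compound 4, `NC(=O)C[C@H](NC(=O)CN(c1ncnc2c1ncn2C1CCCCO1)C1CC1)C(=O)OCc1ccccc1`, has not yet been measured. It differs from compound 3 by carbamoyl in place of hydroxy on a saturated chain carbon, two bonds along the chain from an amide-type nitrogen and a carbonyl carbon. The place of this change is described in exactly the same words as for the pair of compound 1 and compound 2, so it is the same change made on the core of compound 3. Because compound 1 to compound 2 gave a number 23.8 percentage points lower from compound 1 to compound 2 (beyond the scatter), a step of similar direction and size is expected here, namely a number 20.2 percentage points lower from compound 3 to compound 4 (beyond the scatter). Compound 4 is therefore estimated at 12% in this assay, with a likely range from 0% to 28%.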

Compound 4, a percentage reported as activity, at one dose (the size of the read-out at that dose, not a potency): 35%
The estimate for compound 4 lay 23 percentage points below the measured number; measured number outside the range, above it.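

In this assay, putting carbamoyl in place of hydroxy on the core of compound 3 gave a number 2.8 percentage points higher from compound 3 to compound 4 (within the scatter), so the clear fall seen on the other core did not carry over. Set side by side, the two steps disagree, which shows that in this series the result of this change depends on the core that carries it: the same change on two cores in this assay, a number 23.8 percentage points lower (beyond the scatter) from compound 1 to compound 2 and a number 2.8 percentage points higher (within the scatter) from compound 3 to compound 4, 26.6 percentage points apart, beyond the scatter of two such steps. This does not show which feature of the two cores makes the difference, as the pairs differ in more than one place, and two cores give no rule for predicting the step on a third.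

Going by these compounds, it remains open whether another group at this place, such as an amine, a carboxylic acid or a longer chain, would also behave differently on the two cores. Also open, on these data alone, is whether the same disagreement would appear at other doses or times, as each compound here has one reading.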